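The source may report more compounds than this note shows. Statements on the series, on what has been measured and on what is new or still open speak of the compounds shown alone.

Three compounds have been measured so far in an ADME assay on Akata cells (Homo sapiens) for cytotoxicity, with a stated time of 7 days (a higher number here means that more compound is tolerated, a lower number that less compound is tolerated), and each gives a limit and not a number:

- Compound 1 `Nc1nc(OCC(F)(F)F)c2ncn(/C=C3/CC3(CO)CO)c2n1` gives > 20000 nM
- Compound 2 `CC(C)CSc1nc(N)nc2c1ncn2/C=C1/CC1(CO)CO` gives > 20000 nM
- Compound 3 `CCCCCCCCOc1nc(N)nc2c1ncn2/C=C1/CC1(CO)CO` gives > 20000 nM

Compound 1 stands at the limit > 20000 nM and has no exact number of its own. The other two compounds also sit at limits, so the three cannot be ranked. What they share is the limit of > 20000 nM in this assay, at which 3 of the 3 values shown sit, and nothing finer.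

The step followed here leads to compound 4 `CN(C)c1nc(N)nc2c1ncn2/C=C1/CC1(CO)CO` and puts dimethylamino in place of 2,2,2-trifluoroethoxy on an aromatic carbon, with dimethylamino in place of 2,2,2-trifluoroethoxy on an aromatic carbon as the full count of the change.

The measured steps that change the group on that same carbon are a step that the two limits leave unreadable from compound 1 to compound 2 and a step that the two limits leave unreadable from compound 1 to compound 3 and also a step that the two limits leave unreadable from compound 2 to compound 3 with no size to read in any of them. With compound 2 offering only a step that the two limits leave unreadable from compound 1 to compound 2 and compound 3 only a step that the two limits leave unreadable from compound 1 to compound 3 as a guide, no step beyond the usual scatter is expected in either direction in this assay and compound 4 will probably report a limit too.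

The estimated step is a step that the limit leaves unreadable from compound 1 to compound 4 and it rests on a limit.

For compound 4 the expected value is 25000 nM with an estimated range of 10000 nM to 60000 nM around it.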

Compound 4, half-maximal cytotoxic concentration: > 24000 nM
Compound 4: no number, only a limit (the forecaster's own chance of this, stated with the estimate: 85%); the middle value does not contradict the limit.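

In this assay compound 4 gives > 24000 nM, which is a limit and not a number. Its steps from compound 1, compound 2 and compound 3 cannot be read, since those three compounds also stand at a limit: the limit of > 20000 nM in this assay, at which 3 of the 4 values shown sit.

The compounds shown leave open whether changing the group on that aromatic carbon shifts the half-maximal cytotoxic concentration at all, and in which direction.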